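This account rests on a few compounds, and the source may have more. Where it says the series, first, only, none or still open, it means among the compounds named here.

Compound 1 `Cc1ccc2c(NCc3ccc(NC(=O)C4CCN(Cc5ccccc5)CC4)cc3)nc(N3CCCCCC3)nc2c1` is measured in a functional assay on SV5A8 cells (Homo sapiens) for cytotoxicity; on this read-out lower numbers stand for stronger inhibition and higher numbers for weaker inhibition. In this assay compound 1 gives only a limit of the assay, > 6880 nM. Compound 1 therefore stands at the limit of > 6880 nM in this assay, at which 1 of the 2 values shown sits. Compound 2 `Cc1ccc2c(NCc3ccc(NC(=O)C4CCN(Cc5ccc(F)cc5Cl)CC4)cc3)nc(N(C)C)nc2c1` likewise gives only a limit in this assay, > 5910 nM. Compound 2 stands at the limit of > 5910 nM in this assay, at which 1 of the 2 values shown sits. No number places compound 1 within the series; both values shown are limits. Compound 3 `Cc1ccc2c(NCc3ccc(NC(=O)C4CCN(Cc5ccccc5)CC4)cc3)nc(N3CCCC3)nc2c1` differs from compound 1 by pyrrolidin-1-yl in place of azepan-1-yl on an aromatic carbon. Going by the values given here, no measured step of this kind exists; the step that the limit leaves unreadable from compound 1 to compound 3 is expected to stay within the scatter. Compound 3 is expected to give 7000 nM, between 2500 nM and 20000 nM, most likely again reported only as a limit.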

Compound 3, half-maximal inhibitory concentration: > 7790 nM
Compound 3: only a limit was reported; the forecaster's own chance of this, stated with the estimate: 80%; at least 1.1-fold (0.04 log units) between middle value and limit.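

Compound 1 and compound 3 are both reported only as limits in this assay, and the step between them cannot be read. The compounds shown leave open how azepan-1-yl and pyrrolidin-1-yl compare on the shared core.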